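Hydroxy to Butoxy: A Step Away from a Limit

The source may hold more compounds than are shown below. What is called first, only, known or untested is meant among the compounds shown, and "the series" means these compounds.

In a functional assay on HL-60 cells (Homo sapiens) for cytotoxicity, read by WST assay, with a stated time of 48 h (a lower number here means that less compound is needed, a higher number that more compound is needed for the effect), compound 1 `O=C1OC[C@H](Cc2ccccc2)[C@H]1Cc1ccccc1F` gives 72000 nM. Compound 2 `O=C1OC[C@H](Cc2ccccc2)[C@H]1Cc1cccc(O)c1` gives > 100000 nM, which is a limit of the assay and not a number. Compound 2 therefore has no exact place on the scale, and (the limit of > 100000 nM in this assay, at which 1 of the 2 values shown sits).

Compound 3 `CCCCOc1cccc(C[C@H]2C(=O)OC[C@@H]2Cc2ccccc2)c1` differs from compound 2 in one place: butyl in place of hydrogen on an oxygen on an aromatic ring. In other words, hydroxy becomes butoxy. Among the compounds with values here, only one measured step is available, an at least 1.3-fold higher number from compound 1 to compound 2 (0.14 log units; that floor lies within the scatter). It swaps 2-fluorophenyl for 3-hydroxyphenyl and involves no butyl group, so it bears only indirectly on this change. The data give no direct size for adding butyl. Compound 1, at 72000 nM, does show that a number can be read for this core in this assay. A moderate move towards a lower number is therefore expected, with real uncertainty, and a second limit remains possible. The expected change in this assay is an at least 2.8-fold lower number from compound 2 to compound 3 (0.45 log units; beyond the scatter). For compound 3, the estimated value is 35000 nM, with an expected range from 9000 nM to 100000 nM.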

Compound 3, half-maximal effective concentration: 26000 nM
Compound 3: middle estimate off by 1.3-fold (0.13 log units), on the high side; the measured number falls inside the stated range.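

In this assay, butyl in place of hydrogen on an oxygen on an aromatic ring gives an at least 3.8-fold lower number from compound 2 to compound 3 (0.58 log units; beyond the scatter), so this oxygen is a place where a single change moves the result beyond the scatter. Within the data shown here, the earlier pair offered no such reading, since its one measured step, an at least 1.3-fold higher number from compound 1 to compound 2 (0.14 log units; that floor lies within the scatter), swapped one substituted phenyl group for another and its floor stayed within the scatter. The new step is still only a floor and not an exact size, because compound 2 carries a limit of the assay and not a number: the limit of > 100000 nM in this assay, at which 1 of the 3 values shown sits.

With butoxy as the only ether shown here, nothing yet tells whether the length of the chain matters, and a smaller methoxy group or a longer hexyloxy chain would be the natural comparison on the same core. As far as these compounds go, it is also open whether the butyl group's plain carbon chain is what counts, which a chain of similar length ending in an amine or a carboxylic acid could help to show.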